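The source may hold more compounds than are shown below. What is called first, only, known or untested is meant among the compounds shown, and "the series" means these compounds.

The measured compounds, each with its result in a functional assay on HT-1080 cells (Homo sapiens) for antiproliferative activity, read by MTT assay, with a stated time of 72 h; on this read-out lower numbers stand for stronger inhibition and higher numbers for weaker inhibition:

Compound 1 `CCOC(=O)c1cc(-c2cc(OC)c(OC)c(OC)c2)c(-c2cccc(Br)c2)s1`: compound 1 gives > 100000 nM, which is a limit of the assay and not a number.
Compound 2 `CCOC(=O)c1cc(-c2cc(OC)c(OC)c(OC)c2)c(-c2ccc3ccccc3c2)s1`: compound 2 gives 1150 nM.
Compound 3 `COc1cc(-c2cc(C(=O)O)sc2-c2cccc(Br)c2)cc(OC)c1OC`: compound 3 gives > 100000 nM, again a limit of the assay and not a number.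

Compound 4 `COc1cc(-c2cc(C(=O)O)sc2-c2ccc3ccccc3c2)cc(OC)c1OC` has not yet been measured in this assay.

Compound 1 and compound 2 share one core; the difference between them is naphthalen-2-yl in place of 3-bromophenyl on an aromatic carbon. That change gave an at least 86-fold lower number from compound 1 to compound 2 (1.93 log units; beyond the scatter). The same kind of change leads from compound 3 to compound 4: naphthalen-2-yl in place of 3-bromophenyl on an aromatic carbon. The two places are not quite the same: in compound 1 the ring atom two ring bonds away bears an ethoxycarbonyl group (5 heavy atoms), whereas in compound 3 it bears a carboxy group (3 heavy atoms). How the two cores differ is hydrogen in place of ethyl on an oxygen next to a carbonyl group, and in this assay this gave a step that the two limits leave unreadable from compound 1 to compound 3. Both compound 1 and compound 3 sit at the limit of > 100000 nM in this assay, at which 2 of the 3 values shown sit, so whether the two cores start from the same point cannot be read.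

For compound 4 the step in this assay is expected to be an at least 10-fold lower number from compound 3 to compound 4 (1.00 log units; beyond the scatter), set beside the earlier one because the same kind of change gave an at least 86-fold lower number from compound 1 to compound 2 (1.93 log units; beyond the scatter). From the compounds shown here alone, compound 3 gives only a limit, > 100000 nM, so the starting point of the change is unknown and the expectation is wide. Compound 4 is therefore estimated at about 10000 nM, between 1500 nM and 100000 nM.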

Compound 4, half-maximal inhibitory concentration: 13400 nM
Compound 4: middle estimate off by 1.3-fold (0.13 log units), on the low side, and the stated range covers the measured number.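

In this assay, putting naphthalen-2-yl in place of 3-bromophenyl also lowers the number on the core that bears the carboxy group, giving an at least 7.4-fold lower number from compound 3 to compound 4 (0.87 log units; beyond the scatter), so the direction of the change carries over from the core that bears the ethoxycarbonyl group. What this does not show is whether the change is worth the same amount on both cores, and the steps cannot be compared in size: the same change on two cores in this assay, an at least 86-fold lower number (1.93 log units; beyond the scatter) from compound 1 to compound 2 and an at least 7.4-fold lower number (0.87 log units; beyond the scatter) from compound 3 to compound 4; the limit leaves it open whether they differ. The swap from ethoxycarbonyl to carboxy can be read only on the naphthalen-2-yl pair, where hydrogen in place of ethyl gives a 12-fold higher number from compound 2 to compound 4 (1.07 log units; beyond the scatter), while on the 3-bromophenyl pair that step cannot be read, as both compounds sit at a limit of the assay: the limit of > 100000 nM in this assay, at which 2 of the 4 values shown sit.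

The true starting point on each core stays unknown, so the compounds shown leave open how large the gain from naphthalen-2-yl really is. They also leave open whether the same gain would appear with another group at the ring atom that bears the carboxy group, such as a primary amide or a longer ester chain like propoxycarbonyl.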